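Stereoisomer step in a lignan-type series: compound 1 to compound 3

This account rests on a few compounds, and the source may have more. Where it says the series, first, only, none or still open, it means among the compounds named here.

Measured so far:
compound 1 `COc1cc([C@@H](O)[C@H](CO)Oc2c(OC)cc([C@@H](O)[C@H](O)CO)cc2OC)ccc1O` gives > 100000 nM, a limit of the assay.
compound 2 `CCO[C@H](c1ccc(O[C@@H](CO)[C@@H](O)c2ccc(O)c(OC)c2)c(OC)c1)[C@H](CO)c1ccc(O)c(OC)c1` gives 76300 nM.

Within the data shown here, in a functional assay on RAW264.7 cells (Mus musculus) for inhibition, read by Griess assay, with a stated time of 24 h (on this read-out lower numbers stand for stronger inhibition and higher numbers for weaker inhibition), compound 1 sits only at a limit, so its true value is not fixed by a number; it is the one of the two values shown that rests at the limit (the limit of > 100000 nM in this assay, at which 1 of the 2 values shown sits). Compound 2 gives a measured number in this assay. Compound 3 `COc1cc([C@@H](O)[C@@H](CO)Oc2c(OC)cc([C@@H](O)[C@H](O)CO)cc2OC)ccc1O` is to be measured in this assay. It differs from compound 1 by the two compounds have the same atoms and bonds and differ only in configuration as drawn: 1 of 4 stereo elements differ; a stereocentre at a saturated chain carbon is drawn S in compound 1 and R in compound 3. Among the measured compounds shown here, no step between two measured compounds is available here, so the size of this change can only be expected, not read. The expectation is a step of none beyond the usual scatter in this assay, with no direction favoured. Compound 3 is thus estimated at 100000 nM, within a range of 40000 nM to 300000 nM. The estimate corresponds to an expected step of a number no higher from compound 1 to compound 3 (the limit leaves the size open).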

Compound 3, half-maximal inhibitory concentration: > 100000 nM
Compound 3 was reported as a limit (the forecaster's own chance of this, stated with the estimate: 70%); the middle value sits exactly at the limit.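

No step can be read from compound 1 to compound 3, as both values are limits of the assay: the limit of > 100000 nM in this assay, at which 2 of the 3 values shown sit.

Still open, going by these compounds, is whether the stereocentre at the saturated chain carbon, drawn S in compound 1 and R in compound 3, has any effect on inhibition in this assay.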